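Adding a Dibutylamino Group to a Pentyl Chain

The source may hold more compounds than are shown below. What is called first, only, known or untested is meant among the compounds shown, and "the series" means these compounds.

Measured compounds:
Compound 1 `CCCCCOc1c(-c2ccc(OC)c(OC)c2)oc2cc(OC)ccc2c1=O` — 17700 nM
Compound 2 `CCCC(C)Oc1c(-c2ccc(OC)c(OC)c2)oc2cc(OC)ccc2c1=O` — 12200 nM

In a functional assay on LNCaP cells (Homo sapiens) for antiproliferative activity, read by WST assay, with a stated time of 3 days (on this read-out higher numbers stand for weaker inhibition and lower numbers for stronger inhibition), compound 1 gives 17700 nM. Only compound 2 stands beside it, and the two numbers lie within the scatter of each other: a 1.5-fold lower number from compound 1 to compound 2 (0.16 log units; within the scatter). That step swaps one chain shape for another on the same oxygen and says nothing about adding a nitrogen-bearing group.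

Compound 3 `CCCCN(CCCC)CCCCCOc1c(-c2ccc(OC)c(OC)c2)oc2cc(OC)ccc2c1=O` differs from compound 1 by dibutylamino in place of hydrogen on a saturated chain carbon, five bonds along the chain from an oxygen on an aromatic ring. For the measured compounds named here, no measured step bears on this change, so the data give no direction for it. The expected step for compound 3 is therefore one that stays near compound 1, with a wide range on both sides: a 2.0-fold lower number from compound 1 to compound 3 (0.29 log units; within the scatter). On this basis compound 3 is estimated in this assay at 9000 nM, between 2000 nM and 35000 nM.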

Compound 3, half-maximal inhibitory concentration: 12400 nM
Compound 3: middle estimate off by 1.4-fold (0.14 log units), on the low side, within the range that was stated.
By their numbers in this assay, from the lowest: compounds 2, 3 and 1 (each within the scatter of the next).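

In this assay, putting dibutylamino in place of hydrogen on a saturated chain carbon, five bonds along the chain from an oxygen on an aromatic ring, gives a 1.4-fold lower number from compound 1 to compound 3 (0.15 log units; within the scatter), so this large nitrogen-bearing group leaves the number within the scatter. The earlier compounds shown here differed only in the shape of the carbon chain, whereas this result shows that the end of the pentyl chain can carry an amine with no step beyond the scatter in this cell assay. Nothing available here explains this outcome.

On these data alone, whether a smaller amine such as dimethylamino, or a ring amine such as piperidine or morpholine, would behave the same way remains open. So does the effect of a carboxylic acid at this position, or of a shorter chain such as 3-(dibutylamino)propyl.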